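Thioether to benzylamine on the shared diamine core

The compounds below may be only part of what the source reports. "The series", "measured", "known", "first", "only" and "open" are said of these compounds alone.

Measured so far:
compound 1 `CCOC(=O)[C@H](CCC(=O)O)NC(=O)c1ccc(Sc2nc3cc(N)cc(N)c3nc2-c2ccccc2)cc1` — in a functional assay on A549 cells (Homo sapiens) for inhibition, read by sulforhodamine B assay, with a stated time of 48 h (a higher number here means a weaker inhibitor of growth, a lower number a stronger inhibitor of growth), compound 1 gives < 100000 nM
compound 2 `Nc1cc(N)c2nc(-c3ccccc3)c(Sc3ccc(F)cc3)nc2c1` — in this assay compound 2 gives 30900 nM

The value of compound 1 in this assay is a limit, not a number, and nothing more can be drawn from it. Compound 2 therefore stands alone: its value is the only number shown in this assay, the other entry being (the limit of < 100000 nM in this assay, at which 1 of the 2 values shown sits). Among the measured compounds shown here, no step between two measured compounds is available, so there is no measured change of one group against another to lean on.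

Compound 3 `Nc1cc(N)c2nc(-c3ccccc3)c(NCc3ccc(F)cc3)nc2c1` is the next compound to be measured in this assay. It differs from compound 2 in one place: (4-fluorobenzyl)amino in place of (4-fluorophenyl)sulfanyl on an aromatic carbon. The rest of the shared core of compound 2 is unchanged.

With no measured step of this kind in the set, the size of the change expected for a 1.2-fold lower number from compound 2 to compound 3 (0.09 log units; within the scatter) is taken as modest, not clearly beyond the scatter in either direction. Compound 3 is expected at 25000 nM, with a range from 8000 nM to 80000 nM.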

Compound 3, concentration for total growth inhibition: 34700 nM
Compound 3: the middle estimate sits 1.4-fold (0.14 log units) below what was measured, and the stated range covers the measured number.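

In this assay, among the compounds shown here, (4-fluorobenzyl)amino in place of (4-fluorophenyl)sulfanyl on the aromatic carbon next to the ring nitrogen gives the first measured step at this position: a 1.1-fold higher number from compound 2 to compound 3 (0.05 log units; within the scatter). Compound 2 and compound 3 cannot be told apart in this read-out, so here the sulfur-linked group and the amine-linked benzyl group read alike, even though the entering group carries a hydrogen-bond donor that the leaving group lacks. Nothing measured in the series gives a reason for this match.

On these data alone, both groups end in the same 4-fluorophenyl ring, so it remains open whether this carbon would read the same with a group lacking that ring, such as a plain amine, a morpholine or a short chain ending in a carboxylic acid. As far as these compounds go, it also remains open whether a methyl group on the linking nitrogen of compound 3, or a different substituent in place of the ring fluorine, would move the number beyond the scatter.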